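Methoxy in place of chloro on a shared dioxide core

The source may report more compounds than this note shows. Statements on the series, on what has been measured and on what is new or still open speak of the compounds shown alone.

Compound 1 `CC(=O)N(C(C)=O)c1c(C#N)[n+]([O-])c2cc(Cl)ccc2[n+]1[O-]` and compound 2 `Cc1c(C(=O)N=[N+]=[N-])[n+]([O-])c2cc(Cl)ccc2[n+]1[O-]` share a core and were both tested in a functional assay on Ehrlich cells (Mus musculus) for cytotoxicity, read by trypan blue exclusion; a lower number here means a stronger inhibitor, a higher number a weaker inhibitor. In this assay compound 1 reached only the limit of > 100 ug/mL. Compound 2 in turn gives only the limit of > 100 ug/mL in this assay. Among the compounds with values here, every value gathered so far sits at the limit of > 100 ug/mL in this assay, at which 2 of the 2 values shown sit, so no measured step between compounds exists and each value can be described only as a limit.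

Compound 3 `COc1ccc2c(c1)[n+]([O-])c(C(=O)N=[N+]=[N-])c(C)[n+]2[O-]` has not yet been measured. It differs from compound 2 by methoxy in place of chloro on an aromatic carbon. Within the data shown here, with no measured step available to size this change, the step from compound 2 to compound 3 is expected to be small, with no direction beyond the scatter. For compound 3 the expected value in this assay is 150 ug/mL, within a range from 40 ug/mL to 600 ug/mL. The expected step is accordingly a step that the limit leaves unreadable from compound 2 to compound 3.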

Compound 3, half-maximal inhibitory concentration: > 100 ug/mL
Compound 3: a limit, no number; the forecaster's own chance of this, stated with the estimate: 75%; the middle value does not contradict the limit.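

In this assay, within the data shown here, compound 3 gives the limit > 100 ug/mL and no number, so no step from compound 2 to compound 3 can be read. The compounds shown leave open whether methoxy in place of chloro changes cytotoxicity at all, since all stand at one limit: the limit of > 100 ug/mL in this assay, at which 3 of the 3 values shown sit.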